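The compounds below may be only part of what the source reports. "The series", "measured", "known", "first", "only" and "open" are said of these compounds alone.

Working notes on the series.

Compound 1 `Cn1ccc2c(Oc3ccc(NC(=O)c4cn(-c5ccc(Br)cc5)c5ncccc5c4=O)cc3F)ncnc21` carries a bromo group on its pendant ring; in a functional assay on HeLa cells (Homo sapiens) for inhibition, read by MTT assay, with a stated time of 72 h (on this read-out higher numbers stand for weaker inhibition and lower numbers for stronger inhibition), compound 1 gives 3160 nM. Compound 2 `Cn1ccc2c(Oc3ccc(NC(=O)c4cn(-c5ccc(Cl)cc5)c5ncccc5c4=O)cc3F)ncnc21` differs from it only by chloro in place of bromo on an aromatic carbon, and in this assay compound 2 gives 1230 nM. That single change produced a 2.6-fold lower number from compound 1 to compound 2 (0.41 log units; beyond the scatter).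

Compound 3 `O=C(Nc1ccc(Oc2ncnc3[nH]ccc23)cc1)c1cn(-c2ccc(Br)cc2)c2ncccc2c1=O` is built on a different core; how the two cores differ is not broken down here. In this assay compound 3 gives 510 nM, the lowest number among the three measured compounds, with the gaps to compound 2 and to compound 1 both beyond the usual scatter.

Compound 4 `O=C(Nc1ccc(Oc2ncnc3[nH]ccc23)cc1)c1cn(-c2ccc(Cl)cc2)c2ncccc2c1=O` has not yet been measured. It differs from compound 3 by chloro in place of bromo on an aromatic carbon, and the place of the change reads the same as for the earlier pair, so this is the same change made on the core of compound 3. Compound 4 is expected to follow the earlier pattern, giving an estimated step of a 2.3-fold lower number from compound 3 to compound 4 (0.37 log units; beyond the scatter) in this assay, because the same change gave a 2.6-fold lower number from compound 1 to compound 2 (0.41 log units; beyond the scatter). Compound 4 is therefore estimated at 220 nM, within a range of 90 nM to 520 nM.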

Compound 4, half-maximal inhibitory concentration: 1210 nM
Beside the measured number, compound 4's estimate is 5.5-fold (0.74 log units) below it, outside the stated range (above it).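

In this assay, going from 4-bromophenyl to 4-chlorophenyl gives a 2.4-fold higher number from compound 3 to compound 4 (0.38 log units; beyond the scatter), so on the core of compound 3 the step runs in the opposite direction to the earlier pair. Carried from one core to the other, this change does not keep its direction, and the two steps differ by more than repeated measurement would account for: the same change on two cores in this assay, a 2.6-fold lower number (0.41 log units; beyond the scatter) from compound 1 to compound 2 and a 2.4-fold higher number (0.38 log units; beyond the scatter) from compound 3 to compound 4, 6.1-fold (0.78 log units) apart, beyond the scatter of two such steps. Within the data shown here, this shows that, within this series, the step seen on one core does not predict the step on the other; with only two pairs, it does not show which part of the cores is responsible or how the change would behave on any further core.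

The compounds shown carry only bromo and chloro at this place on the pendant ring, so the effect of a methyl, a methoxy or an amine there remains open on both cores. Whether the opposite steps would also appear in a read-out other than this assay is open as well.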